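The source may report more compounds than this note shows. Statements on the series, on what has been measured and on what is new or still open speak of the compounds shown alone.

Within the data shown here, in a functional assay on MCF7 cells (Homo sapiens) for antiproliferative activity, read by MTT assay, with a stated time of 72 h (on this read-out higher numbers stand for weaker inhibition and lower numbers for stronger inhibition), compound 3 `COc1ncc(-c2ccc3c(c2)N(c2ccccc2)C(=O)CO3)cc1NS(=O)(=O)c1ccc(F)cc1` gives 8870 nM, the lower of the two numbers so far. Compound 1 `COc1ccc(N2C(=O)COc3ccc(-c4cnc(Cl)c(NS(=O)(=O)c5ccc(F)cc5)c4)cc32)cc1` gives 36000 nM, a higher number, with the gap beyond the scatter. Compound 2 `COc1cccc(N2C(=O)COc3ccc(-c4cnc(OC)c(NS(=O)(=O)c5ccc(F)cc5)c4)cc32)c1` gives > 40000 nM, which is a limit of the assay and not a number.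

Compound 4 `COc1ccc(N2C(=O)COc3ccc(-c4cnc(OC)c(NS(=O)(=O)c5ccc(F)cc5)c4)cc32)cc1` is not yet measured. Its difference from compound 3 is methoxy in place of hydrogen on an aromatic carbon, or phenyl to 4-methoxyphenyl when cut one bond further out.

Among the measured compounds shown here, one measured step bears on this change: an at least 4.5-fold lower number from compound 2 to compound 3 (0.65 log units; beyond the scatter), with hydrogen in place of methoxy on an aromatic carbon. It is the same exchange run the other way, though the place of the methoxy need not carry over. Compound 1 also bears the 4-methoxyphenyl group and sits at 36000 nM, but it differs from compound 4 elsewhere, so it is weaker support.

In this assay a higher number of modest size, beyond the scatter, is therefore expected. The expected change is a 3.0-fold higher number from compound 3 to compound 4 (0.48 log units; beyond the scatter). For compound 4 the estimated value is 27000 nM, with an expected range of 12000 nM to 60000 nM.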

Compound 4, half-maximal inhibitory concentration: 8260 nM
Compound 4: middle estimate off by 3.3-fold (0.51 log units), on the high side; the measured number lies below the stated range.
By their numbers in this assay, from the lowest: compounds 4 and 3 (each within the scatter of the next); then compound 1. At a limit, above all of these: compound 2.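

In this assay, methoxy on the aromatic carbon para to a large group gives a 1.1-fold lower number from compound 3 to compound 4 (0.03 log units; within the scatter), so phenyl and 4-methoxyphenyl cannot be told apart here, which the earlier step with the methoxy at another place on that ring did not show. The place of the methoxy does separate two compounds, with an at least 4.8-fold lower number from compound 2 to compound 4 (0.68 log units; beyond the scatter), and the value of compound 2 is a limit of the assay and not a number: the limit of > 40000 nM in this assay, at which 1 of the 4 values shown sits. With 4-methoxyphenyl held fixed, the exchange on the shared core gives a 4.4-fold lower number from compound 1 to compound 4 (0.64 log units; beyond the scatter), so in this pair the higher number goes with chloro and not with the 4-methoxyphenyl group.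

On these data alone, whether an amine, a hydroxyl or a longer chain such as butoxy at the same place would also stay within the scatter of compound 3 remains open. As far as these compounds go, the comparison of chloro and methoxy rests on one pair, so it remains open whether it holds with phenyl in place of 4-methoxyphenyl, or how a methyl or an amine would read on that carbon of the shared core.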